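Chloro added to the dichlorophenyl group of compound 3

The compounds below may be only part of what the source reports. "The series", "measured", "known", "first", "only" and "open" are said of these compounds alone.

Measured so far in an ADME assay on H9c2 cells (Rattus norvegicus) for cytotoxicity, read by resazurin assay, with a stated time of 72 h (a lower number here means that less compound is tolerated, a higher number that more compound is tolerated), for three compounds:
- Compound 1 `C/C(=N\Nc1nc(-c2ccccc2)cs1)c1ccc(Cl)c(Cl)c1` gives > 50000 nM as a limit
- Compound 2 `C/C(=N\Nc1nc(-c2ccc(C)cc2)cs1)c1ccc(Cl)c(Cl)c1` gives > 50000 nM as a limit
- Compound 3 `C/C(=N\Nc1nc(-c2ccc(Cl)cc2Cl)cs1)c1ccc(Cl)c(Cl)c1` gives > 50000 nM as a limit

Compound 3 stands at > 50000 nM as a limit and not as a number. Within the data shown here, the series so far offers only the limit of > 50000 nM in this assay, at which 3 of the 3 values shown sit, as its reading. The move to compound 4 `C/C(=N\Nc1nc(-c2ccc(Cl)c(Cl)c2Cl)cs1)c1ccc(Cl)c(Cl)c1` puts chloro in place of hydrogen on an aromatic carbon, ortho to two chloro groups and meta to a large group, counted as chloro in place of hydrogen on an aromatic carbon in full. Among the measured compounds shown here, three measured steps bear on it, all of them changes on an aromatic carbon: a step that the two limits leave unreadable from compound 1 to compound 2 and a step that the two limits leave unreadable from compound 1 to compound 3 and a step that the two limits leave unreadable from compound 2 to compound 3 in this series. None of them has a readable size, so no size carries over. For compound 4 no step beyond the scatter is expected in this assay and another limit is the likeliest report. The estimated step is a number no higher from compound 3 to compound 4 (the limit leaves the size open) on this reading. For compound 4 the expected value is 50000 nM with an estimated range from 20000 nM to 100000 nM overall.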

Compound 4, half-maximal cytotoxic concentration: 17000 nM
Beside the measured number, compound 4's estimate is 2.9-fold (0.47 log units) above it; the measured number lies below the stated range.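

In this assay, chloro in place of hydrogen on an aromatic carbon, ortho to two chloro groups and meta to a large group, gives an at least 2.9-fold lower number from compound 3 to compound 4 (0.46 log units; beyond the scatter). Among these compounds, this position is therefore the first place where a change has a readable effect, towards less compound tolerated, whereas the earlier steps on the other aromatic ring cannot be read. Compound 4 is the only compound shown with a number rather than a limit: the limit of > 50000 nM in this assay, at which 3 of the 4 values shown sit.

The compounds shown leave open whether a methoxy group or an amine at this same place would also lower the number, and whether chloro there would do so without the two chloro groups it sits ortho to. From the compounds shown here alone, the full size of the step also stays open, as compound 3 has only a limit.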